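The source may hold more compounds than are shown below. What is called first, only, known or untested is meant among the compounds shown, and "the series" means these compounds.

Compound 1 `COc1ccc(OC)c(/C=N/NC(=O)Nc2ccc(Oc3ccnc(-c4nncn4CCN(C)C)c3)c(F)c2)c1` gives 2930 nM in a functional assay on NCI-H460 cells (Homo sapiens) for cytotoxicity, read by MTT assay, with a stated time of 72 h; a higher number here means a weaker inhibitor, a lower number a stronger inhibitor.
Compound 2 `CN(C)CCn1cnnc1-c1cc(Oc2ccc(NC(=O)N/N=C/c3cccc(Cl)c3Cl)cc2F)ccn1` gives 72 nM in this assay.

For the measured compounds named here, compound 1 stands highest of these two numbers, and the single measured step away from it is large: a 41-fold lower number from compound 1 to compound 2 (1.61 log units; beyond the scatter). Compound 3 `CN(C)CCn1cnnc1-c1cc(Oc2ccc(NC(=O)N/N=C/c3ccc(O)cc3)cc2F)ccn1` differs from compound 1 by 4-hydroxyphenyl in place of 2,5-dimethoxyphenyl on a carbon with a double bond to nitrogen. Going by the values given here, the one step measured at this carbon shows that exchanging the aryl group there can move the number a long way, but it covers a different group, so the direction for 4-hydroxyphenyl is uncertain. Compound 3 is expected to land somewhat lower than compound 1, by a 3.3-fold lower number from compound 1 to compound 3 (0.51 log units; beyond the scatter). Compound 3 is estimated at 900 nM, with a range of 150 nM to 5000 nM.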

Compound 3, half-maximal inhibitory concentration: 1780 nM
Compound 3: middle estimate off by 2.0-fold (0.30 log units), on the low side; the range from low to high includes it.
By their numbers in this assay, from the lowest: compound 2; then compounds 3 and 1 (each within the scatter of the next).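

In this assay, the step with a 1.6-fold lower number from compound 1 to compound 3 (0.22 log units; within the scatter) stays within the scatter, so 4-hydroxyphenyl and 2,5-dimethoxyphenyl on the carbon with a double bond to nitrogen are not told apart. Among the three aryl groups, only 2,3-dichlorophenyl stands apart, and the step with a 25-fold higher number from compound 2 to compound 3 (1.39 log units; beyond the scatter) confirms this from a second comparison. No measurement offered here explains this difference.

Going by these compounds, it remains open whether compound 2 owes its low number to both chlorines or to one of them. On these data alone, how an aryl group bearing an amine or a carboxylic acid would read at this carbon also remains open.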